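The compounds below may be only part of what the source reports. "The series", "measured", "known", "first", "only" and "open" are said of these compounds alone.

Working notes on a series of anilide carboxylic acids bearing a sulfonylated five-membered ring. Compound 2 `Cc1ccc(S(=O)(=O)N2CC(O)C[C@H]2C(=O)Nc2ccc(C(=O)O)cc2)cc1` is the reference point; in a functional assay on the whole organism for inhibition, with Rattus norvegicus as the target, read by paw edema, with a stated time of 1 h, at a dose of 100 mg/kg by the oral route (a lower number here means less inhibition, a higher number more inhibition at the dose given (going by the name of the read-out)), compound 2 gives 60%. Compound 1 `O=C(O)c1ccc(NC(=O)[C@@H]2CC(O)CN2S(=O)(=O)c2ccc([N+](=O)[O-])cc2)cc1` carries nitro in place of methyl on an aromatic carbon, and in this assay compound 1 gives 48.5%, a step of a number 11.5 percentage points lower from compound 2 to compound 1 (beyond the scatter). Compound 3 `Cc1ccc(S(=O)(=O)N2CCC[C@H]2C(=O)Nc2ccc(C(=O)O)cc2)cc1` differs from compound 2 by hydrogen in place of hydroxy on a saturated ring carbon; in this assay compound 3 gives 31.5%, a step of a number 28.5 percentage points lower from compound 2 to compound 3 (beyond the scatter). Among the three measured compounds, compound 3 stands lowest, with both of its steps to the others beyond the scatter. Compound 1 and compound 2 differ from each other only at the aryl sulfonyl group, while the two cores, that of compound 2 and that of compound 3, differ by the hydroxy-to-hydrogen exchange described above.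

Compound 4 `O=C(O)c1ccc(NC(=O)[C@@H]2CCCN2S(=O)(=O)c2ccc([N+](=O)[O-])cc2)cc1` is not yet measured. It relates to compound 3 by nitro in place of methyl on an aromatic carbon, which is the same change as that from compound 2 to compound 1, with the place described in identical terms. On the core of compound 2 that change gave a number 11.5 percentage points lower from compound 2 to compound 1 (beyond the scatter). Applied to the core of compound 3, which already starts from the lowest measured value 31.5%, a step of similar size is expected for compound 4, namely a number 11.5 percentage points lower from compound 3 to compound 4 (beyond the scatter). This expectation rests on a single precedent, so its width is taken generously. Compound 4 is therefore expected to give about 20% in this assay, within a range from 5% to 35%.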

Compound 4, a percentage reported as inhibition, in the whole organism at one dose (the size of the read-out at that dose, not a potency): 45.9%
Compound 4: the middle estimate sits 25.9 percentage points below what was measured; the measured number lies above the stated range.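

In this assay the exchange of 4-methylphenyl for 4-nitrophenyl does not carry from one core to the other, since the new step, a number 14.4 percentage points higher from compound 3 to compound 4 (beyond the scatter), runs in the opposite direction to the earlier one: the same change on two cores in this assay, a number 11.5 percentage points lower (beyond the scatter) from compound 2 to compound 1 and a number 14.4 percentage points higher (beyond the scatter) from compound 3 to compound 4, 25.9 percentage points apart, beyond the scatter of two such steps

The exchange of hydroxy for hydrogen on the saturated ring carbon does not carry either, since with the 4-nitrophenyl group the step is only a number 2.6 percentage points lower from compound 1 to compound 4 (within the scatter), and the clear drop seen with the 4-methylphenyl group does not recur: the same change on two cores in this assay, a number 28.5 percentage points lower (beyond the scatter) from compound 2 to compound 3 and a number 2.6 percentage points lower (within the scatter) from compound 1 to compound 4, 25.9 percentage points apart, beyond the scatter of two such steps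

So in these four compounds the effect of each change depends on what occupies the other place, but this rests on one set of four compounds at a single dose and time, and it shows neither the reason for the dependence nor whether it extends to any other group.

Going by these compounds, it remains open whether a chloro or methoxy group on the aromatic carbon para to a large group would behave like methyl or like nitro on each of the two cores. On these data alone, it is equally open whether a methoxy group or a fluorine atom in place of the hydroxy on the saturated ring carbon would give the same dependence.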